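The compounds below may be only part of what the source reports. "The series", "measured", "known", "first", "only" and "open" are said of these compounds alone.

Of the compounds shown here, three built on one shared core have been tested in a functional assay on the whole organism (strain Wistar) for inhibition, with Rattus norvegicus as the target, read by paw edema, with stated times of 60 min and 3 h, at a dose of 100 mg/kg by the oral route; on this read-out higher numbers stand for more inhibition at the one dose given (going by the name of the read-out) and lower numbers for less inhibition. Compound 1 `CCNC(=O)CC1CCc2cc(OC)c(OC)cc21` gives 26.1%. Compound 2 `CCN(CC)C(=O)CC1CCc2cc(OC)c(OC)cc21` gives 37.7%. Compound 3 `COc1cc2c(cc1OC)C(CC(=O)NC(C)(C)C)CC2` gives 33.3%. Compound 3 thus sits close to both of the others: the step of a number 4.4 percentage points lower from compound 2 to compound 3 (within the scatter) and the step of a number 7.2 percentage points higher from compound 1 to compound 3 (within the scatter) each stay within the scatter, so no ranking of compound 3 against compound 2 or compound 1 can be read from these numbers. Going by the values given here, the only step that goes beyond the scatter is a number 11.6 percentage points higher from compound 1 to compound 2 (beyond the scatter), where ethyl replaces hydrogen on the amide-type nitrogen.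

Compound 4 `COc1cc2c(cc1OC)C(CC(=O)NC1CCCCC1)CC2` differs from compound 3 in a single place: cyclohexyl in place of tert-butyl on an amide-type nitrogen. Among the compounds with values here, the steps that bear on this are the ones that alter the group on the amide-type nitrogen. Putting a carbon group where hydrogen stood gave the step of a number 11.6 percentage points higher from compound 1 to compound 2 (beyond the scatter), but swapping one carbon group for another, as in a number 7.2 percentage points higher from compound 1 to compound 3 (within the scatter), stayed within the scatter. The change to compound 4 is of this second kind, an exchange of one carbon group for another. For compound 4 the expected step is a number 0.3 percentage points lower from compound 3 to compound 4 (within the scatter), nothing beyond the scatter. Compound 4 is therefore estimated at 33%, with a range from 22% to 45%.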

Compound 4, a percentage reported as inhibition, in the whole organism at one dose (the size of the read-out at that dose, not a potency): 49.3%
For compound 4 the middle estimate is 16.3 percentage points below the measured one; measured number above the stated range.
By their numbers in this assay, from the lowest: compounds 1, 3 and 2 (each within the scatter of the next, the first and the last beyond it); then compound 4.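

At the amide-type nitrogen, exchanging one carbon group for another can matter after all: in this assay the change from ethyl to tert-butyl stayed within the scatter, but cyclohexyl in place of tert-butyl gives a number 16 percentage points higher from compound 3 to compound 4 (beyond the scatter). The gain also holds against the other two compounds, with a number 11.6 percentage points higher from compound 2 to compound 4 (beyond the scatter) and a number 23.2 percentage points higher from compound 1 to compound 4 (beyond the scatter), so compound 4 is the only one of the four whose steps to all the others are printed as beyond the scatter, and it stands highest at this one dose. Nothing measured here accounts for this gain, so the numbers record the effect of the change without explaining it.

Cyclohexyl differs from tert-butyl both in its count of carbon atoms and in carrying a ring, and the compounds shown do not separate these two differences; an open hexyl chain or a cyclopentyl ring on the same nitrogen would bear on that question. Going by these compounds, it also remains open whether a phenyl ring there would match cyclohexyl, and whether the order of the compounds would hold at other doses.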